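Replacing a small amine by a larger ringed group

This account rests on a few compounds, and the source may have more. Where it says the series, first, only, none or still open, it means among the compounds named here.

Two compounds share one core and differ only in the group on a saturated chain carbon bound to an aromatic carbon. Compound 1, `O=C(NCc1cc(C(F)(F)F)cc(C(F)(F)F)c1)c1c(CCl)nc2ccccc2c1-c1ccccc1`, carries a chloro there, and in an in vitro assay on UC11MG cells for binding affinity to Substance-P receptor (Homo sapiens), read by radioligand binding (a lower number here means a stronger inhibitor, a higher number a weaker inhibitor), compound 1 gives 26 nM. Within the data shown here, compound 2, `CN(C)Cc1nc2ccccc2c(-c2ccccc2)c1C(=O)NCc1cc(C(F)(F)F)cc(C(F)(F)F)c1`, carries a dimethylamino in that place, and in this assay compound 2 gives 0.22 nM, the lowest of the two numbers so far; the change gave a 120-fold lower number from compound 1 to compound 2 (2.07 log units; beyond the scatter).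

Compound 3, `O=C(NCc1cc(C(F)(F)F)cc(C(F)(F)F)c1)c1c(CN2C(=O)c3ccccc3C2=O)nc2ccccc2c1-c1ccccc1`, is the next variation: a group of 11 heavy atoms (8 carbon, 1 nitrogen, 2 oxygen; one five-membered non-aromatic ring with 1 hetero atom, one six-membered aromatic ring of carbon only) in place of a group of 3 heavy atoms (2 carbon, 1 nitrogen; no ring), on a saturated chain carbon bound to an aromatic carbon. Among the measured compounds shown here, the only measured step shows that the group on this carbon matters a great deal, since swapping chloro for dimethylamino gave a 120-fold lower number from compound 1 to compound 2 (2.07 log units; beyond the scatter). For the measured compounds named here, no step shows what happens when the dimethylamino itself is replaced by a much larger group, so the direction is uncertain, but a group so different in size and make-up is unlikely to leave the number unchanged. Compound 3 is therefore expected to land between the two measured compounds, with the step of a 36-fold higher number from compound 2 to compound 3 (1.56 log units; beyond the scatter). The estimate for compound 3 in this assay is 8 nM, within a range of 0.8 nM to 80 nM.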

Compound 3, half-maximal inhibitory concentration: > 1000 nM
Compound 3 was reported as a limit; the forecaster's own chance of this, stated with the estimate: 5%; at least 120-fold (2.09 log units) between middle value and limit.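

In this assay, compound 3 is reported only as a limit, not as a number: the limit of > 1000 nM in this assay, at which 1 of the 3 values shown sits.

Even so, the comparisons are clear. Putting the ringed group in place of the dimethylamino gave an at least 4500-fold higher number from compound 2 to compound 3 (3.65 log units; beyond the scatter), while putting it in place of the chloro gave an at least 38-fold higher number from compound 1 to compound 3 (1.58 log units; beyond the scatter). Among these compounds, the earlier pair showed only that a change on this saturated chain carbon could lower the number; these steps show that a change there can also raise it steeply, past even the chloro compound, so the three groups run dimethylamino, chloro, ringed group from the lowest number to the highest.

The ringed group differs from the dimethylamino at once in its heavy atoms, its rings and its double bonds outside aromatic rings, and the compounds shown cannot tell which of these differences matters. Nor do they show where along this range of groups the number begins to climb, which a diethylamino group, a piperidine ring or a simple primary amine on the same carbon could begin to answer.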